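Replacing 2-chloropyridin-4-yl with 3-(methanesulfonamido)phenyl

This account rests on a few compounds, and the source may have more. Where it says the series, first, only, none or still open, it means among the compounds named here.

Three compounds share one core and differ only in the aromatic group attached to it: compound 1 `O=C(O)Cc1sc(C(c2ccc(F)cc2)c2ccc(F)cc2)nc1-c1ccnc(N2CCC2)c1`, compound 2 `O=C(O)Cc1sc(C(c2ccc(F)cc2)c2ccc(F)cc2)nc1-c1cc(F)nc(F)c1` and compound 3 `O=C(O)Cc1sc(C(c2ccc(F)cc2)c2ccc(F)cc2)nc1-c1ccnc(Cl)c1`. In an in vitro functional assay on HEK285-7 cells for antagonist activity at prostaglandin D2 receptor 2 (Homo sapiens), read by BRET and beta-arrestin recruitment (a lower number here means a smaller maximal response, a higher number a larger maximal response), compound 1 gives 80%, compound 2 gives 80% and compound 3 gives 80%, so compound 3 stands level with both. The measured steps were no change at the digits printed from compound 1 to compound 2 (within the scatter), no change at the digits printed from compound 1 to compound 3 (within the scatter) and no change at the digits printed from compound 2 to compound 3 (within the scatter). Compound 4 `CS(=O)(=O)Nc1cccc(-c2nc(C(c3ccc(F)cc3)c3ccc(F)cc3)sc2CC(=O)O)c1` differs from compound 3 by 3-(methanesulfonamido)phenyl in place of 2-chloropyridin-4-yl on an aromatic carbon. Every measured step altered only the groups on the six-membered aromatic ring with 1 hetero atom, none exchanged that ring for a ring of carbon only, so they bear on this change only loosely; each stayed within the scatter. Compound 4 is therefore expected to show no change at the digits printed from compound 3 to compound 4 (within the scatter), an estimated 80%, ranging from 65% to 95%.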

Compound 4, largest response reached (reported as efficacy), in percent of the reference or control that the assay uses: 80%
Compound 4: the middle estimate sits on the measured number at the digits printed; low and high end bracket the measured number.
By their numbers in this assay, from the lowest: compounds 1, 2, 3 and 4 (each within the scatter of the next).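

In this assay, exchanging the six-membered aromatic ring with 1 hetero atom for a ring of carbon only gives no change at the digits printed from compound 3 to compound 4 (within the scatter). The comparisons with the other two compounds read the same: no change at the digits printed from compound 2 to compound 4 (within the scatter) and no change at the digits printed from compound 1 to compound 4 (within the scatter). This position therefore tolerates both that ring exchange and a larger group bearing a hydrogen-bond donor, although nothing shown explains why the response holds level. Still open, going by these compounds, is whether a carboxylic acid or a primary amine on the carbon ring, or a longer chain replacing the ring, would leave the response equally unchanged.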